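Extending the propylamino chain of compound 3

The source may report more compounds than this note shows. Statements on the series, on what has been measured and on what is new or still open speak of the compounds shown alone.

In an in vitro assay on HEK-tsA201 cells for antagonist activity at Neuronal acetylcholine receptor; alpha3/beta4 (Homo sapiens), read by fluorescence and calcium flux (a lower number here means a stronger inhibitor, a higher number a weaker inhibitor), compound 1 `CCCOc1ccc(C(=O)Nc2cccc(Cl)n2)cc1` sits at the limit > 100000 nM, which is a limit and not a number. Compound 2 `CCCOc1ccc(C(=O)Nc2cccc(CC)n2)cc1` gives 29200 nM and compound 3 `CCCNc1cccc(NC(=O)c2ccc(OCCC)cc2)n1` gives 12600 nM, the lowest of the two numbers, with a 2.3-fold lower number from compound 2 to compound 3 (0.37 log units; beyond the scatter) and an at least 7.9-fold lower number from compound 1 to compound 3 (0.89 log units; beyond the scatter). Compound 4 `CCCCCCNc1cccc(NC(=O)c2ccc(OCCC)cc2)n1` differs by propyl in place of hydrogen on a saturated chain carbon, three bonds along the chain from a nitrogen on an aromatic ring. Among the measured compounds shown here, no measured step changes a chain carbon; all three concern the group on the aromatic carbon, so none bears directly on this step. A change at most modest, in either direction, is expected in this assay. The step expected is a 1.4-fold lower number from compound 3 to compound 4 (0.15 log units; within the scatter). Compound 4 is estimated at 9000 nM, within 2500 nM to 30000 nM.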

Compound 4, half-maximal inhibitory concentration: > 100000 nM
Compound 4 ended at the assay's limit; the forecaster's own chance of this, stated with the estimate: 10%; at least 11-fold (1.04 log units) between middle value and limit.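

In this assay, among the compounds shown here, the first change on a saturated chain carbon reverses the gain seen on the aromatic carbon, with an at least 7.9-fold higher number from compound 3 to compound 4 (0.89 log units; beyond the scatter). Hexylamino also reads weaker than ethyl, with an at least 3.4-fold higher number from compound 2 to compound 4 (0.53 log units; beyond the scatter), so an amino group there does not by itself secure the lower number of compound 3. The step from compound 1 to compound 4 cannot be read: both values are limits.

The compounds shown leave open where between propylamino and hexylamino the number rises, which butylamino and pentylamino would locate. From the compounds shown here alone, how a terminal hydroxyl on the chain would read also remains open.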